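Pyridyl isomer swap on a thiazolyl-amine series: exposure outlook

A few compounds are considered here, and "the series" means these few. Any claim that something is new, unique, unknown or untested is made for them only; others in the source may bear on it.

Compound 3 `Cc1cn2c(-c3cn[nH]c3)cnc2c(Nc2cc(Cc3ccncc3)ns2)n1` has in an ADME assay on the whole organism for pharmacokinetics, with Rattus norvegicus as the target, with a stated time of 6 h, at a dose of 10 mg/kg by the oral route (a higher number here means more compound in the circulation at the dose given, a lower number less compound in the circulation), the result "not determined" (no result reported); no single number is available for it. Its analogues set the frame: in this assay compound 1 `Cc1cn2c(-c3cn[nH]c3)cnc2c(Nc2cc(Cc3nccs3)ns2)n1` gives 1540 ng.h/mL, and compound 2 `Cc1cn2c(-c3cn[nH]c3)cnc2c(Nc2cc(Cc3ncccn3)ns2)n1` gives 701 ng.h/mL, the step being a 2.2-fold lower number from compound 1 to compound 2 (0.34 log units; beyond the scatter). Compound 4 `Cc1ccc(Cc2cc(Nc3nc(C)cn4c(-c5cn[nH]c5)cnc34)sn2)nc1` differs from compound 3 by 5-methylpyridin-2-yl in place of pyridin-4-yl on a saturated chain carbon bound to an aromatic carbon. Among the measured compounds shown here, the one measured step, a 2.2-fold lower number from compound 1 to compound 2 (0.34 log units; beyond the scatter), concerns a different exchange on the same saturated chain carbon, so it bears on the present change only loosely, suggesting that such swaps move this assay modestly rather than strongly. With no number for compound 3, the expectation for compound 4 rests on compounds 1 and 2 alone. Compound 4 is therefore expected to give about 1000 ng.h/mL, within the range 300 ng.h/mL to 3000 ng.h/mL.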

Compound 4, area under the concentration-time curve: 1370 ng.h/mL
Estimate against measurement, compound 4: 1.4-fold (0.14 log units) below; the measured number falls inside the stated range.
By their numbers in this assay, from the lowest: compounds 2, 4 and 1 (each within the scatter of the next, the first and the last beyond it).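

In this assay the entry of 5-methylpyridin-2-yl on the saturated chain carbon gives a 2.0-fold higher number from compound 2 to compound 4 (0.29 log units; within the scatter) and a 1.1-fold lower number from compound 1 to compound 4 (0.05 log units; within the scatter) and so places this group within the scatter of both earlier groups, although those two lie apart. The step from compound 3 to compound 4 cannot be read, so this change itself remains without a size. No evidence on the compounds accounts for these numbers.

The compounds shown leave open how a phenyl ring on this carbon, or a longer chain carrying the same rings, would stand in this assay.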